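Halogen swap on the phenoxy chain: working notes

The source may report more compounds than this note shows. Statements on the series, on what has been measured and on what is new or still open speak of the compounds shown alone.

Measured in a functional assay on A549 cells (Homo sapiens) for antiproliferative activity, read by MTT assay, with a stated time of 72 h; on this read-out higher numbers stand for weaker inhibition and lower numbers for stronger inhibition:
compound 1 `NC1=NC2(CCOCC2)N(OCCCOc2ccccc2Cl)C(N)=N1` gives 2700 nM
compound 2 `NC1=NC2(CCOCC2)N(OCCCOc2ccccc2Br)C(N)=N1` gives 160 nM
compound 3 `NC1=NC2(CCOCC2)N(OCCCOc2cccc(Br)c2)C(N)=N1` gives 160 nM

Compound 4 `NC1=NC2(CCOCC2)N(OCCCOc2cccc(Cl)c2)C(N)=N1` is not yet measured in this assay. It differs from compound 3 by chloro in place of bromo on an aromatic carbon. The same change, (chloro in place of bromo on an aromatic carbon), occurs twice among these compounds and has one measured instance, a 17-fold higher number from compound 2 to compound 1 (1.23 log units; beyond the scatter). The cores of compound 2 and compound 3 differ by 3-bromophenyl in place of 2-bromophenyl on an oxygen on a saturated carbon, which gave no change at the digits printed from compound 2 to compound 3 (within the scatter). The change from compound 3 to compound 4 is the same kind of change as that from compound 2 to compound 1, not the same: in one the halogen sits ortho to a large group, in the other meta to a large group. Because the measured instance a 17-fold higher number from compound 2 to compound 1 (1.23 log units; beyond the scatter) is large, a higher number is expected for compound 4. With the place differing, for compound 4 a smaller step is expected, a 3.8-fold higher number from compound 3 to compound 4 (0.57 log units; beyond the scatter). Compound 4 is estimated at 600 nM, between 150 nM and 3000 nM.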

Compound 4, half-maximal inhibitory concentration: 150 nM
Compound 4: middle estimate off by 4.0-fold (0.60 log units), on the high side; measured number inside the range.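

In this assay, chloro in place of bromo on an aromatic carbon does not carry over from one core to the other: the same change on two cores in this assay, a 17-fold higher number (1.23 log units; beyond the scatter) from compound 2 to compound 1 and a 1.1-fold lower number (0.03 log units; within the scatter) from compound 3 to compound 4, 18-fold (1.26 log units) apart, beyond the scatter of two such steps. With the 3-bromophenyl changed to 3-chlorophenyl the swap gives a 1.1-fold lower number from compound 3 to compound 4 (0.03 log units; within the scatter), compound 2 and compound 4 stay level with a 1.1-fold lower number from compound 2 to compound 4 (0.03 log units; within the scatter), and only compound 1 stands apart, with an 18-fold lower number from compound 1 to compound 4 (1.26 log units; beyond the scatter). So a step measured on one core cannot be assumed for the other, but two pairs give no general rule for the series and do not show why the steps differ.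

Still open, from the compounds shown here alone, is whether fluoro or methoxy in place of the halogen would follow compound 1 or compound 4, and whether a longer chain would keep the same picture.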